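Shortening the Diene Chain of Compound 2

The source may hold more compounds than are shown below. What is called first, only, known or untested is meant among the compounds shown, and "the series" means these compounds.

In a functional assay on the whole organism with Rattus norvegicus as the target (a lower number here means that less compound is needed, a higher number that more compound is needed for the effect), compound 1 `C/C=C\C=C\[C@](C)(O)C/C=C/[C@H]1[C@H](O)CC(=O)[C@@H]1CC/C=C\CCC(=O)OC` gives 0.306 mg/kg and compound 2 `C/C=C(C)\C=C\[C@](C)(O)C/C=C/[C@H]1[C@H](O)CC(=O)[C@@H]1CC/C=C\CCC(=O)OC` gives 1.23 mg/kg, the higher of the two numbers. Compound 3 `C=C/C(C)=C/[C@](C)(O)C/C=C/[C@H]1[C@H](O)CC(=O)[C@@H]1CC/C=C\CCC(=O)OC` has 2-methylbuta-1,3-dien-1-yl in place of 3-methylpenta-1,3-dien-1-yl on a saturated chain carbon bound to an oxygen on a saturated carbon and two saturated chain carbons. Among the compounds with values here, only one measured step bears on this change: a 4.0-fold higher number from compound 1 to compound 2 (0.60 log units; beyond the scatter), a modest rise beyond the scatter when methyl replaced hydrogen on the chain. That single step is a weak guide to a different change, so in this assay the expected result is a 1.4-fold lower number from compound 2 to compound 3 (0.14 log units; within the scatter), which stays within the scatter. Compound 3 is estimated at 0.9 mg/kg, with an expected range of 0.3 mg/kg to 3 mg/kg.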

Compound 3, dose for half-maximal effect: 1.03 mg/kg
Compound 3: the middle estimate sits 1.1-fold (0.06 log units) below what was measured; measured number inside the range.
By their numbers in this assay, from the lowest: compound 1; then compounds 3 and 2 (each within the scatter of the next).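

In this assay, 2-methylbuta-1,3-dien-1-yl in place of 3-methylpenta-1,3-dien-1-yl gives a 1.2-fold lower number from compound 2 to compound 3 (0.08 log units; within the scatter), so this chain can lose one carbon and carry its methyl elsewhere with no readable change. The same group in place of penta-1,3-dien-1-yl gives a 3.4-fold higher number from compound 1 to compound 3 (0.53 log units; beyond the scatter), so both methyl-bearing dienes shown here need more compound than the diene without a methyl. No supporting data explain these differences. Going by these compounds, whether an amine, a carboxylic acid or a saturated pentyl chain on this carbon would retain the effect remains open.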